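Working notes: 4-fluorophenyl for 3,4-dimethylphenyl on compound 2

The compounds below may be only part of what the source reports. "The series", "measured", "known", "first", "only" and "open" are said of these compounds alone.

compound 1 `CCN1CCc2ccc(-n3cc(C(=O)N4CCC(F)CC4)c4cc(OC)c(OC)cc4c3=O)cc21` — 120 nM
compound 2 `COc1cc2c(C(=O)N3CCCCCC3)cn(-c3ccc(C)c(C)c3)c(=O)c2cc1OC` — 720 nM

Both were tested in an assay on CHO cells for antagonist activity at lysophosphatidic acid receptor 5 (Rattus norvegicus), read by cAMP accumulation, with a stated time of 30 min; on this read-out higher numbers stand for weaker inhibition and lower numbers for stronger inhibition. Compound 2 has the higher of the two numbers there; its gap to compound 1 lies beyond the usual scatter, but the two differ in several places, so no single change can be read from it.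

Compound 3 `COc1cc2c(C(=O)N3CCCCCC3)cn(-c3ccc(F)cc3)c(=O)c2cc1OC` is compound 2 with 4-fluorophenyl in place of 3,4-dimethylphenyl on an aromatic nitrogen. For the measured compounds named here, no measured pair isolates this change, so the step from compound 2 to compound 3 is expected to stay within the scatter, a 1.3-fold higher number from compound 2 to compound 3 (0.10 log units; within the scatter). Compound 3 is estimated at 900 nM, with a range from 300 nM to 3000 nM.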

Compound 3, half-maximal inhibitory concentration: > 3000 nM
Compound 3: only a limit was reported; the forecaster's own chance of this, stated with the estimate: 10%; middle value at least 3.3-fold (0.52 log units) away from the limit.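

For the compounds shown here, on the aromatic nitrogen, the first single-place change is not neutral: in this assay, 4-fluorophenyl in place of 3,4-dimethylphenyl gives an at least 4.1-fold higher number from compound 2 to compound 3 (0.61 log units; beyond the scatter). Compound 3 is reported only as a limit, > 3000 nM, not as a number. The step therefore gives only a minimum size, set by that limit: the limit of > 3000 nM in this assay, at which 1 of the 3 values shown sits.

A 4-methylphenyl or plain phenyl group on this nitrogen would help separate the part played by the two methyl groups from that of the fluorine. Going by these compounds, whether the same change carries over to the amide of compound 1 remains open.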